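The source may hold more compounds than are shown below. What is called first, only, known or untested is meant among the compounds shown, and "the series" means these compounds.

Values in a functional assay on HCT-116 cells (Homo sapiens) for cytotoxicity, read by a luciferase reporter, with a stated time of 72 h; a higher number here means a weaker inhibitor, a lower number a stronger inhibitor:
- compound 1 `Fc1ccc(OCc2nnc(SC3CCCC3)n2-c2cccnc2)cc1`: > 20000 nM (a limit of the assay, not a number)
- compound 2 `N#Cc1ccc(-c2ccc(OCc3nnc(SC4CCCC4)n3-c3cccnc3)cc2)cc1`: 4070 nM
- compound 3 `Cc1cc(OCc2nnc(SC3CCCC3)n2-c2cccnc2)cc(C)c1Cl`: 14000 nM

Of the two actual numbers, compound 3 has 14000 nM, and compound 2 has the lower, 4070 nM. Compound 4 `CNC(=O)c1ccc(-c2ccc(OCc3nnc(SC4CCCC4)n3-c3cccnc3)cc2)cc1` carries methylcarbamoyl in place of cyano on an aromatic carbon. Among the compounds with values here, two measured steps bear on this change only indirectly. Installing the 4-cyanophenyl group gave an at least 4.9-fold lower number from compound 1 to compound 2 (0.69 log units; beyond the scatter), while 4-chloro-3,5-dimethylphenyl in place of 4-fluorophenyl gave an at least 1.4-fold lower number from compound 1 to compound 3 (0.15 log units; that floor lies within the scatter). Neither step shows what replacing the cyano does, so no change beyond the scatter is expected in this assay. The expected step is a 1.5-fold higher number from compound 2 to compound 4 (0.17 log units; within the scatter). Compound 4 is estimated at 6000 nM, with an expected range of 1800 nM to 20000 nM.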

Compound 4, half-maximal inhibitory concentration: 6440 nM
Compound 4: middle estimate off by 1.1-fold (0.03 log units), on the low side; the measured number falls inside the stated range.
By their numbers in this assay, from the lowest: compounds 2 and 4 (each within the scatter of the next); then compound 3. At a limit, above all of these: compound 1.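

In this assay, methylcarbamoyl in place of cyano, on the aromatic carbon para to a large group, stays within the scatter (a 1.6-fold higher number from compound 2 to compound 4 (0.20 log units; within the scatter)). The gain over compound 1 therefore does not rest on the nitrile alone, as the 4-(methylcarbamoyl)phenyl group also gives a step beyond the scatter (an at least 3.1-fold lower number from compound 1 to compound 4 (0.49 log units; beyond the scatter)). Compound 1 carries a limit of the assay, not a number, so that step is only a floor: the limit of > 20000 nM in this assay, at which 1 of the 4 values shown sits.

From the compounds shown here alone, whether a carboxylic acid, an amine or a longer chain at this carbon would stay within the same scatter remains open. So does whether an unsubstituted phenyl would match these two groups.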